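A few compounds are considered here, and "the series" means these few. Any claim that something is new, unique, unknown or untested is made for them only; others in the source may bear on it.

Of the compounds shown here, three built on one shared core have been measured. Compound 1 `Cc1nn(C)c(-n2cccc2)c1/C=N/OCc1ccc(C(=O)OC(C)(C)C)cc1` carries a 1H-pyrrol-1-yl group, and in a functional assay on A549 cells (Homo sapiens) for cytotoxicity (on this read-out lower numbers stand for stronger inhibition and higher numbers for weaker inhibition), compound 1 gives 1.64 ug/mL. Compound 2 `Cc1nn(C)c(N2CCCC2)c1/C=N/OCc1ccc(C(=O)OC(C)(C)C)cc1` carries pyrrolidin-1-yl in the same place, and in this assay compound 2 gives 0.13 ug/mL, which amounts to a 13-fold lower number from compound 1 to compound 2 (1.10 log units; beyond the scatter). Compound 3 `Cc1nn(C)c(-n2ccnc2)c1/C=N/OCc1ccc(C(=O)OC(C)(C)C)cc1` carries 1H-imidazol-1-yl there, and in this assay compound 3 gives 5.93 ug/mL, the highest of the three numbers; relative to the others this is a 3.6-fold higher number from compound 1 to compound 3 (0.56 log units; beyond the scatter) and a 46-fold higher number from compound 2 to compound 3 (1.66 log units; beyond the scatter), so compound 3 is the weakest inhibitor of the three.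

Compound 4 `Cc1nn(C)c(-n2cccn2)c1/C=N/OCc1ccc(C(=O)OC(C)(C)C)cc1` is not yet measured. It differs from compound 3 in a single place: 1H-pyrazol-1-yl in place of 1H-imidazol-1-yl on an aromatic carbon. Within the data shown here, no measured step exchanges one of these two rings for the other, so the guide is indirect. The closest comparison is the exchange of 1H-pyrrol-1-yl for 1H-imidazol-1-yl, a 3.6-fold higher number from compound 1 to compound 3 (0.56 log units; beyond the scatter), a modest move, and the exchange for pyrrolidin-1-yl, a 13-fold lower number from compound 1 to compound 2 (1.10 log units; beyond the scatter), a large one in the other direction. Since compound 3 and compound 4 share both atoms and ring size, the step in this assay is expected to be small and may stay within the scatter. Compound 4 is expected to give about 3.5 ug/mL, ranging from 1.2 ug/mL to 10 ug/mL. This corresponds to an expected step of a 1.7-fold lower number from compound 3 to compound 4 (0.23 log units; within the scatter).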

Compound 4, half-maximal inhibitory concentration: 2.49 ug/mL
For compound 4 the middle estimate is 1.4-fold (0.15 log units) above the measured one, within the range that was stated.
By their numbers in this assay, from the lowest: compound 2; then compounds 1 and 4 (each within the scatter of the next); then compound 3.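

In this assay the two rings that leave and enter have the same atoms and the same counts, and only the way they are joined differs, yet the change at this position is still visible (a 2.4-fold lower number from compound 3 to compound 4 (0.38 log units; beyond the scatter)), a modest step beyond the usual scatter. Compound 4 also sits within the scatter of the ring in compound 1 (a 1.5-fold higher number from compound 1 to compound 4 (0.18 log units; within the scatter)), so the 1H-pyrazol-1-yl and 1H-pyrrol-1-yl groups cannot be told apart here, while compound 3 with its 1H-imidazol-1-yl group stays the weakest of the four. The large step to the pyrrolidin-1-yl compound (a 19-fold higher number from compound 2 to compound 4 (1.28 log units; beyond the scatter)) now holds against a third aromatic ring, leaving compound 2 the strongest of the four.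

Nothing available explains why these rings differ. On these data alone, it also remains open whether an open-chain amine such as dimethylamino or a six-membered piperidin-1-yl ring at this position would match compound 2, and whether a carboxylic acid in place of the tert-butyl ester would change the order of these rings.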